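A step from compound 3 to compound 4

The compounds below may be only part of what the source reports. "The series", "measured", "known", "first", "only" and "open" are said of these compounds alone.

Compound 3 `CCCn1c(=O)[nH]c2nc(-c3ccc(S(=O)(=O)N4CCN(c5ccc(I)cc5)CC4)cc3)[nH]c2c1=O` carries a 4-iodophenyl group on an amine nitrogen in a ring. In an assay on CHO cells for displacement of a labelled ligand from adenosine receptor A3 (Homo sapiens), read by scintillation counting, with a stated time of 45 min, in the presence of a further agent that is not named here (on this read-out higher numbers stand for weaker inhibition and lower numbers for stronger inhibition), compound 3 gives > 1000 nM, which is a limit of the assay and not a number. Compound 1 `CCCn1c(=O)[nH]c2nc(-c3ccc(S(=O)(=O)N4CCN(C)CC4)cc3)[nH]c2c1=O` gives > 1000 nM in this assay, likewise a limit. Compound 2 `CCCn1c(=O)[nH]c2nc(-c3ccc(S(=O)(=O)N4CCN(c5ccccc5)CC4)cc3)[nH]c2c1=O` gives > 1000 nM in this assay, again a limit. The steps a step that the two limits leave unreadable from compound 1 to compound 2, a step that the two limits leave unreadable from compound 1 to compound 3 and a step that the two limits leave unreadable from compound 2 to compound 3 therefore cannot be read, because the limit of > 1000 nM in this assay, at which 3 of the 3 values shown sit, hides their size. Compound 4 `CCCn1c(=O)[nH]c2nc(-c3ccc(S(=O)(=O)N4CCN(c5cccc(Cl)c5)CC4)cc3)[nH]c2c1=O` differs from compound 3 in one place: 3-chlorophenyl in place of 4-iodophenyl on an amine nitrogen in a ring. Going by the values given here, no measured step bears readably on this change, so no direction can be drawn from the earlier compounds. Since compound 3 sits at the limit, compound 4 is expected to stay there as well, with a step that the limit leaves unreadable from compound 3 to compound 4 meaning no change beyond the scatter. Compound 4 is estimated at 3000 nM in this assay, within a range from 1000 nM to 10000 nM.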

Compound 4, inhibition constant: 53.5 nM
Beside the measured number, compound 4's estimate is 56-fold (1.75 log units) above it; the measured number lies below the stated range.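

In this assay, going by these compounds alone, the 3-chlorophenyl group on the amine nitrogen in the ring gives the first readable steps: an at least 18-fold lower number from compound 3 to compound 4 (1.27 log units; beyond the scatter) against 4-iodophenyl, an at least 18-fold lower number from compound 2 to compound 4 (1.27 log units; beyond the scatter) against phenyl, and an at least 18-fold lower number from compound 1 to compound 4 (1.27 log units; beyond the scatter) against methyl. Within the data shown here, the 4-iodophenyl and 3-chlorophenyl groups match in heavy-atom count, aromatic ring, hydrogen-bond donors and acceptors, and charge, so this position responds strongly to a change of halogen and its place on the phenyl ring, which the earlier compounds could not show. The steps among the three earlier compounds cannot be read, because their values are limits: the limit of > 1000 nM in this assay, at which 3 of the 4 values shown sit.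

The compounds shown do not separate the identity of the halogen from its place, a question that 4-chlorophenyl and 3-iodophenyl would address. They also leave open whether 3-methoxyphenyl or 3-methylphenyl would serve at this position as well as 3-chlorophenyl.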